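The source may hold more compounds than are shown below. What is called first, only, known or untested is meant among the compounds shown, and "the series" means these compounds.

Compound 1, `N=C(N)Nc1cccc(C(=O)NNC(=O)NC(CC(=O)O)c2cccc3ccccc23)c1`, and compound 2, `N=C(N)Nc1cccc(C(=O)NNC(=O)NC(CC(=O)O)c2cc(Cl)cc(Cl)c2)c1`, share one core and differ in that compound 2 carries 3,5-dichlorophenyl in place of naphthalen-1-yl on a saturated chain carbon bound to an amide-type nitrogen and a saturated chain carbon. In a physicochemical assay for lipophilicity (a lower number here means a more polar compound, a higher number a more lipophilic compound), compound 1 gives 1.7, and compound 2 gives 1.82, so that the step is a number 0.12 log units higher from compound 1 to compound 2 (within the scatter). Compound 3, `O=C(O)CC(NC(=O)NNC(=O)CCCCNc1ccccn1)c1cccc2ccccc12`, stands on a second core; the difference between the two cores is a group of 11 heavy atoms (9 carbon, 2 nitrogen; one six-membered aromatic ring with 1 hetero atom) in place of a group of 10 heavy atoms (7 carbon, 3 nitrogen; one six-membered aromatic ring of carbon only), on a carbonyl carbon. In this assay compound 3 gives 2.64, which is a number 0.94 log units higher from compound 1 to compound 3 (beyond the scatter). Among the three measured compounds compound 3 has the highest number; compound 2 is the nearest to it and compound 1 the furthest.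

Compound 4, `O=C(O)CC(NC(=O)NNC(=O)CCCCNc1ccccn1)c1cc(Cl)cc(Cl)c1`, has not been measured. It differs from compound 3 by 3,5-dichlorophenyl in place of naphthalen-1-yl on a saturated chain carbon bound to an amide-type nitrogen and a saturated chain carbon, which is the same change, at the same place, as that from compound 1 to compound 2. The step in this assay is therefore expected to be a number 0.12 log units higher from compound 3 to compound 4 (within the scatter). That expectation rests on the step of a number 0.12 log units higher from compound 1 to compound 2 (within the scatter) seen on the core of compound 1. Compound 4 is expected to give 2.76 in this assay, with a range from 2.35 to 3.2.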

Compound 4, partition coefficient: 2.76
Compound 4: the middle estimate sits on the measured number at the digits printed; the range from low to high includes it.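

In this assay the step of a number 0.12 log units higher from compound 1 to compound 2 (within the scatter) on the core of compound 1 is matched at the printed digits by a number 0.12 log units higher from compound 3 to compound 4 (within the scatter) on the second core, so 3,5-dichlorophenyl in place of naphthalen-1-yl carries over between these two cores. For the compounds shown here, both steps lie within the scatter, however, so the match shows only that the exchange leaves the number about where it was on each core; it does not show that a step beyond the scatter would carry over, or that the agreement would hold on any further core. Nothing measured here offers an explanation for the agreement between the two steps.

The compounds shown leave open whether the same agreement would appear with other groups at this place, such as a plain phenyl or a pyridine ring. They also leave open whether it would survive on a core with a primary amide in place of the carboxylic acid.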